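The compounds below may be only part of what the source reports. "The series", "measured", "known", "first", "only" and "open" are said of these compounds alone.

Values measured in an ADME assay on HEK293 cells (Homo sapiens) for cytotoxicity, read by CCK-8 assay, with a stated time of 48 h (a lower number here means a stronger inhibitor, a higher number a weaker inhibitor), follow.

- compound 1 `COc1ccc(/C=C\c2cc(OC)c(OC)c(OC)c2)cc1OCc1ccc(CO)cc1` gives 37000 nM
- compound 2 `COc1ccc(/C=C\c2cc(OC)c(OC)c(OC)c2)cc1OCc1ccc(CN2CC(C(=O)O)C2)cc1` gives > 50000 nM as a limit of the assay, not a number
- compound 3 `COc1ccc(/C=C\c2cc(OC)c(OC)c(OC)c2)cc1OCc1ccc(CN2CC[C@H](O)C2)cc1` gives > 50000 nM as a limit of the assay, not a number

Compound 3 has no exact value, only the limit > 50000 nM in this assay. The same limit is shared with one other compound: the limit of > 50000 nM in this assay, at which 2 of the 3 values shown sit.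

Compound 4 `COc1ccc(/C=C\c2cc(OC)c(OC)c(OC)c2)cc1OCc1ccc(CNCCNC(C)=O)cc1` keeps the shared core and changes one group: (2-acetamidoethyl)amino in place of 3-hydroxypyrrolidin-1-yl on a saturated chain carbon bound to an aromatic carbon. In words, (2-acetamidoethyl)amino takes the place of 3-hydroxypyrrolidin-1-yl on a saturated chain carbon bound to an aromatic carbon.

Within the data shown here, three measured steps bear on this change. Two replace hydroxy at that same place: an at least 1.3-fold higher number from compound 1 to compound 2 (0.13 log units; that floor lies within the scatter) and an at least 1.3-fold higher number from compound 1 to compound 3 (0.13 log units; that floor lies within the scatter). The third swaps one ring group for another: a step that the two limits leave unreadable from compound 2 to compound 3. Neither ring group gave a number, so compound 4 is expected to lie close to the limit, given the value of compound 3 (> 50000 nM).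

The expected change is a number no higher from compound 3 to compound 4 (the limit leaves the size open), and no step beyond the scatter is expected. The estimate for compound 4 is 50000 nM, with an expected range from 22000 nM to 100000 nM.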

Compound 4, half-maximal inhibitory concentration: > 50000 nM
Compound 4 gave a limit, no number; the forecaster's own chance of this, stated with the estimate: 65%; the middle value sits exactly at the limit.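

In this assay, the open chain (2-acetamidoethyl)amino, which has no ring, ends at the same limit as the two ring groups at this saturated chain carbon, so among these compounds a ring in this group is not required for that outcome: the limit of > 50000 nM in this assay, at which 3 of the 4 values shown sit. Set against the hydroxy group, this change gives an at least 1.3-fold higher number from compound 1 to compound 4 (0.13 log units; that floor lies within the scatter), so this step, like the two before it, cannot be shown to exceed the usual scatter. The steps from compound 2 and compound 3 to compound 4 cannot be read, as each joins two limits.

On these data alone, how far compound 2, compound 3 and compound 4 lie past the limit stays open, and so does their order. Also open, as far as these compounds go, is whether a simple primary amine or a shorter chain ending in a carboxylic acid at this place would give a measurable number.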